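The source may hold more compounds than are shown below. What is called first, only, known or untested is meant among the compounds shown, and "the series" means these compounds.

In a functional assay on A549 cells (Homo sapiens) for cytotoxicity, read by MTT assay, with a stated time of 72 h (on this read-out lower numbers stand for stronger inhibition and higher numbers for weaker inhibition), compound 3 `O=C(CN1CCN(c2nnc(Cc3ccccc3)c3ccccc23)CC1)Nc1ccc(F)c(F)c1` gives 10100 nM, the highest number of the three measured. Compound 2 `O=C(CN1CCN(c2nnc(Cc3ccccc3)c3ccccc23)CC1)Nc1ccc(F)c(C(F)(F)F)c1` gives 2480 nM and compound 1 `O=C(CN1CCN(c2nnc(Cc3ccncc3)c3ccccc23)CC1)Nc1cccc(Br)c1` gives 1530 nM.

Compound 4 `O=C(CN1CCN(c2nnc(Cc3ccccc3)c3ccccc23)CC1)Nc1cccc(F)c1` is made from compound 3 by one change: hydrogen in place of fluoro on an aromatic carbon. This puts hydrogen in place of fluoro on an aromatic carbon, turning 3,4-difluorophenyl into 3-fluorophenyl.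

Among the measured compounds shown here, the only measured single-place step on this ring is a 4.1-fold higher number from compound 2 to compound 3 (0.61 log units; beyond the scatter). It is modest, but it exchanges a different group, and the fluoro that leaves here stays unchanged through that step. It therefore bears only indirectly on the size of this change. Compound 1 differs from compound 4 in more than one place and offers no clean comparison. For the measured compounds named here, no measured pair shows the loss of a fluoro group, so the direction is poorly defined.

A small step is expected, a 1.4-fold lower number from compound 3 to compound 4 (0.16 log units; within the scatter), leaning to a lower number only since compound 3 sits at the top of the measured values with 10100 nM. For compound 4 the estimated value is 7000 nM, with an expected range of 2800 nM to 18000 nM.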

Compound 4, half-maximal inhibitory concentration: 130000 nM
For compound 4 the middle estimate is 19-fold (1.27 log units) below the measured one; measured number above the stated range.
By their numbers in this assay, from the lowest: compounds 1 and 2 (each within the scatter of the next); then compound 3; then compound 4.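

In this assay, among the compounds shown here, the fluoro para to a large group proves far from silent: taking 3,4-difluorophenyl to 3-fluorophenyl gives a 13-fold higher number from compound 3 to compound 4 (1.11 log units; beyond the scatter) and is the first measured loss of a fluoro on this ring. For the compounds shown here, this step is larger than a 4.1-fold higher number from compound 2 to compound 3 (0.61 log units; beyond the scatter) even though only one fluoro leaves, so a substituent at this place matters more than the earlier compounds showed. Across the ring as a whole, the change gives a 52-fold higher number from compound 2 to compound 4 (1.72 log units; beyond the scatter) and leaves compound 4 with the highest number of the series. Nothing measured here accounts for the size of this step.

Still open, from the compounds shown here alone, is whether the gain depends on fluoro itself or on any group at this place, such as chloro, methoxy or an amine. Also open, going by these compounds, is whether the same step holds with the pyridinylmethyl group of compound 1 on the core.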